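A Chlorobenzyl Swap Made at the Cytotoxicity Limit

The compounds below may be only part of what the source reports. "The series", "measured", "known", "first", "only" and "open" are said of these compounds alone.

Compound 1 `O=C1c2ccccc2N(COCc2ccccc2)S(=O)(=O)N1Cc1ccccc1`: > 122000 nM
Compound 2 `O=C1c2ccccc2N(Cc2ccc(Cl)c(Cl)c2)S(=O)(=O)N1Cc1ccccc1`: > 200000 nM

Both compounds were tested in a functional assay on HEL cells (Homo sapiens) for inhibition; a lower number here means that less compound is tolerated, a higher number that more compound is tolerated. Compound 1 gives > 122000 nM, which is a limit of the assay rather than a measured number. Compound 2 gives > 200000 nM, likewise a limit. Compound 1 sits at the limit of > 122000 nM in this assay, at which 1 of the 2 values shown sits. Compound 2 sits at the limit of > 200000 nM in this assay, at which 1 of the 2 values shown sits. Among the compounds with values here, the single step between them, a step that the two limits leave unreadable from compound 1 to compound 2, is therefore unreadable in size and direction. Compound 2 thus stands at a limit, with no measured number beside it to compare against.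

Compound 3 `O=C1c2ccccc2N(Cc2ccccc2Cl)S(=O)(=O)N1Cc1ccccc1` differs from compound 2 by 2-chlorophenyl in place of 3,4-dichlorophenyl on a saturated chain carbon bound to a sulfonamide nitrogen in a ring. Within the data shown here, no measured step speaks to this change in a readable way, since the only step in the set is hidden by the two limits. For the step of a number no higher from compound 2 to compound 3 (the limit leaves the size open) no movement beyond the usual scatter is therefore expected. Compound 3 is estimated at 200000 nM, within a range from 100000 nM to 400000 nM, and the assay is most likely to report only a limit for it once more.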

Compound 3, half-maximal cytotoxic concentration: 88000 nM
The estimate for compound 3 lay 2.3-fold (0.36 log units) above the measured number, outside the stated range (below it).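

In this assay, compound 3 is the only one of the three shown that gives a measured number rather than a limit, 88000 nM, so the group on the saturated chain carbon bound to a sulfonamide nitrogen in a ring can now be linked to a readable change. Going from 3,4-dichlorobenzyl to 2-chlorobenzyl gives an at least 2.2-fold lower number from compound 2 to compound 3 (0.35 log units; beyond the scatter), which shows that this swap lowers the tolerated amount by more than the usual scatter, and the true step may be larger still, since one end of it is a limit. The comparison with the benzyloxy group gives an at least 1.3-fold lower number from compound 1 to compound 3 (0.14 log units; that floor lies within the scatter), and that floor does not separate the two compounds beyond the scatter.

Nothing measured here explains why the number falls with this swap. A plain benzyl group, or a benzyl group carrying an amine, at this same place would help show whether chlorine matters here at all, and the compounds shown leave that question open, along with whether the lower number belongs to the 2-chlorobenzyl group alone.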